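Changing one aryl group on a shared core

The source may report more compounds than this note shows. Statements on the series, on what has been measured and on what is new or still open speak of the compounds shown alone.

In a functional assay on MCF7 cells (Homo sapiens) for antiproliferative activity, read by MTT assay, with stated times of 24 h and 72 h (on this read-out higher numbers stand for weaker inhibition and lower numbers for stronger inhibition), compound 1 `COc1ccc([C@@H]2[C@H](Oc3ccccc3)C(=O)N2c2cc(OC)c(OC)c(OC)c2)cc1OC` gives 26000 nM and compound 2 `COc1cc([C@@H]2[C@H](Oc3ccccc3)C(=O)N2c2cc(OC)c(OC)c(OC)c2)ccc1O` gives 32000 nM while compound 3 `COc1cc(N)c([C@@H]2[C@H](Oc3ccccc3)C(=O)N2c2cc(OC)c(OC)c(OC)c2)cc1O` gives 20000 nM on the same read-out. These three numbers lie within the usual scatter of one another, so compound 3 stands level with the other two and no order among them can be claimed.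

Compound 4 `COc1cc(N2C(=O)[C@@H](Oc3ccccc3)[C@H]2c2ccc(N)cc2)cc(OC)c1OC` keeps the shared core and differs from compound 3 in one group. The change is a group of 7 heavy atoms (6 carbon, 1 nitrogen; one six-membered aromatic ring of carbon only) in place of a group of 10 heavy atoms (7 carbon, 1 nitrogen, 2 oxygen; one six-membered aromatic ring of carbon only), on a saturated ring carbon and the incoming group is 4-aminophenyl, on a saturated ring carbon of a four-membered non-aromatic ring with 1 nitrogen.

The closest evidence comes from changes to this same group. These are a 1.2-fold higher number from compound 1 to compound 2 (0.09 log units; within the scatter) together with a 1.3-fold lower number from compound 1 to compound 3 (0.11 log units; within the scatter) and a 1.6-fold lower number from compound 2 to compound 3 (0.20 log units; within the scatter) as the third step. All three stay within the scatter, so altering this group has not yet moved the number. Among the compounds with values here, the group in compound 4 carries fewer heavy atoms than any measured here, however, and no measured compound shows what that does, so the range must stay wide.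

No shift beyond the scatter is expected, and the estimated change is a 1.3-fold higher number from compound 3 to compound 4 (0.10 log units; within the scatter) on this evidence. The estimate for compound 4 is 25000 nM with an expected range of 8000 nM to 60000 nM as its lower and upper ends.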

Compound 4, half-maximal inhibitory concentration: 160000 nM
For compound 4 the middle estimate is 6.4-fold (0.81 log units) below the measured one, outside the stated range (above it).
By their numbers in this assay, from the lowest: compounds 3, 1 and 2 (each within the scatter of the next); then compound 4.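

This position can clearly move the number in this assay: 4-aminophenyl weakens inhibition against all three earlier groups (an 8.0-fold higher number from compound 3 to compound 4 (0.90 log units; beyond the scatter); a 5.0-fold higher number from compound 2 to compound 4 (0.70 log units; beyond the scatter); a 6.2-fold higher number from compound 1 to compound 4 (0.79 log units; beyond the scatter)), each step beyond the scatter, whereas the steps among the earlier groups all stayed within it. Compound 3 also carries an amino group on this ring, alongside two oxygen-bearing groups, and stays level with compounds 1 and 2, so an amino group here does not by itself go with the higher number; among these four compounds, only compound 4 has no oxygen on this ring. Nothing available explains why this change weakens inhibition.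

Still open, from the compounds shown here alone, is whether the higher number of compound 4 comes with the missing oxygen-bearing groups or with an amino group standing alone on the ring, since both differences arrive together in this one change. A plain phenyl group, a 4-hydroxyphenyl or a 4-methoxyphenyl at this place would help pull these two apart.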